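Piperazine nitrogen substituent in the pan-FGFR-type amide series

A few compounds are considered here, and "the series" means these few. Any claim that something is new, unique, unknown or untested is made for them only; others in the source may bear on it.

Measured so far:
compound 1 `COc1cc(OC)c(Cl)c(-c2ccc3c(NC(=O)c4ccc(N5CCN(C(C)C)CC5)cc4)n[nH]c3n2)c1Cl` — 1.4 nM
compound 2 `COc1cc(OC)c(Cl)c(-c2ccc3c(NC(=O)c4cnc(N5CCN(C)CC5)cn4)n[nH]c3n2)c1Cl` — 60.6 nM

In a functional assay on NCI-H1581 cells (Homo sapiens) for antiproliferative activity, read by CCK-8 assay, with a stated time of 72 h (a lower number here means a stronger inhibitor, a higher number a weaker inhibitor), compound 1 gives 1.4 nM, the lowest number of the two. Compound 2 gives 60.6 nM, a higher number well beyond the scatter, so compound 1 stands clearly ahead on the numbers shown.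

Compound 3 `COc1cc(OC)c(Cl)c(-c2ccc3c(NC(=O)c4ccc(N5CCNCC5)cc4)n[nH]c3n2)c1Cl` is not yet measured. Relative to compound 1 the change is hydrogen in place of isopropyl on an amine nitrogen in a ring.

Among the measured compounds shown here, no measured pair of this kind exists in the set, so the expectation rests on the closeness of the two structures. A small step toward a higher number is expected, a 2.1-fold higher number from compound 1 to compound 3 (0.33 log units; beyond the scatter), most likely within the scatter. Compound 3 is estimated at 3 nM, with a range of 1 nM to 10 nM.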

Compound 3, half-maximal inhibitory concentration: 1.4 nM
Compound 3: the middle estimate sits 2.1-fold (0.33 log units) above what was measured; the range from low to high includes it.
By their numbers in this assay, from the lowest: compounds 1 and 3 (each within the scatter of the next); then compound 2.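

In this assay, among the compounds shown here, the change from 4-isopropylpiperazin-1-yl to piperazin-1-yl reads no change at the digits printed from compound 1 to compound 3 (within the scatter) and gives the first direct reading at this amine nitrogen in a ring. On this pair, the isopropyl group can leave and hydrogen can enter with no difference beyond the scatter. Nothing available explains this result.

On these data alone, whether a longer chain, an acetyl group or a chain ending in a carboxylic acid on this nitrogen would hold the number remains open. Compound 2 differs from compound 1 in more than one place, so it cannot settle the role of this substituent.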